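Swapping cyclopropyl for methyl on a sulfonyl sulfur

The source may hold more compounds than are shown below. What is called first, only, known or untested is meant among the compounds shown, and "the series" means these compounds.

In a physicochemical assay for lipophilicity, read by HPLC, at pH 7.5 (on this read-out higher numbers stand for higher lipophilicity and lower numbers for lower lipophilicity), compound 1 `CCOc1ccccc1-c1ccc(-c2nc3cnccc3c(C[C@H](C)C(=O)O)c2C#N)cc1` gives 2.2. Compound 2 `CCOc1ccccc1-c1ccc(-c2nc3cnccc3c(N[C@H](CC)C(=O)NS(=O)(=O)C3CC3)c2C#N)cc1` gives 2.3, and this gap lies within the usual scatter of repeated measurements, so the two numbers cannot be told apart. Compound 3 `CCOc1ccccc1-c1ccc(-c2nc3cnccc3c(N[C@H](CC)C(=O)NS(C)(=O)=O)c2C#N)cc1` differs from compound 2 by having methyl in place of cyclopropyl on a sulfonyl sulfur. For the measured compounds named here, no measured pair shows this change, so the expectation rests only on the entering methyl being the smaller group. In this assay, the estimated step is a number 0.40 log units lower from compound 2 to compound 3 (beyond the scatter), a modest fall slightly beyond the scatter. The estimated value for compound 3 is 1.9, expected to lie from 1.5 to 2.2.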

Compound 3, distribution coefficient: 2.2
Estimate against measurement, compound 3: 0.30 log units below; the measured number falls inside the stated range.
By their numbers in this assay, from the lowest: compounds 1, 3 and 2 (each within the scatter of the next).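

In this assay, methyl in place of cyclopropyl on a sulfonyl sulfur gives a number 0.10 log units lower from compound 2 to compound 3 (within the scatter) and so the two compounds cannot be told apart, despite the loss of the three-membered ring. The much larger swap on the aromatic carbon gives no change at the digits printed from compound 1 to compound 3 (within the scatter) and leaves those two indistinguishable as well. Nothing measured here explains either result.

On these data alone, whether an ethyl group, a longer chain or an amine on the sulfonyl sulfur would also stay within the scatter remains open.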